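Methyl for Chloro on the Fused Ring of Compound 3

A few compounds are considered here, and "the series" means these few. Any claim that something is new, unique, unknown or untested is made for them only; others in the source may bear on it.

Measured compounds in an assay for inhibition of acyl-CoA (8-3)-desaturase (Homo sapiens); a higher number here means a weaker inhibitor, a lower number a stronger inhibitor:
compound 1 `O=C(Nc1cccc(Cl)c1)c1ccccc1O` with 174 nM
compound 2 `Fc1ccc2[nH]nc(Nc3cccc(Cl)c3)c2c1` with 58 nM
compound 3 `Clc1cccc(Nc2n[nH]c3ccc(Cl)cc23)c1` with 5 nM

Compound 3 stands lowest of the three numbers in this assay. Its nearest neighbour is compound 2, at a value higher by a margin that lies beyond the scatter, and compound 1 sits further away still. Compound 3 and compound 2 share the same core and differ at one aromatic carbon, where the step of a 12-fold lower number from compound 2 to compound 3 (1.06 log units; beyond the scatter) shows how much that single position moved the number.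

Compound 4 `Cc1ccc2[nH]nc(Nc3cccc(Cl)c3)c2c1` has not yet been measured. It differs from compound 3 in one place: methyl in place of chloro on an aromatic carbon. Within the data shown here, the only measured step that bears on this position is a 12-fold lower number from compound 2 to compound 3 (1.06 log units; beyond the scatter), which was large; no measured pair tests methyl against chloro, so the direction for compound 4 rests on that one comparison alone. Since a small halogen at this carbon gave compound 2 a much higher number than compound 3, the expectation is that methyl will also give a somewhat higher number than chloro, though by a smaller margin. The expected step is a 3.0-fold higher number from compound 3 to compound 4 (0.48 log units; beyond the scatter). Compound 4 is therefore estimated at 15 nM in this assay, with a likely range from 4 nM to 60 nM.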

Compound 4, half-maximal inhibitory concentration: 6 nM
Compound 4: the middle estimate sits 2.5-fold (0.40 log units) above what was measured, and the stated range covers the measured number.
By their numbers in this assay, from the lowest: compounds 3 and 4 (each within the scatter of the next); then compound 2; then compound 1.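

In this assay, among these compounds, the change from chloro to methyl on this aromatic carbon gave a 1.2-fold higher number from compound 3 to compound 4 (0.08 log units; within the scatter), so the two groups cannot be told apart at this position, a comparison that the earlier compounds could not offer. The step of a 9.7-fold lower number from compound 2 to compound 4 (0.99 log units; beyond the scatter) shows that fluoro stands apart from methyl as well as from chloro, and it sits alongside the earlier 12-fold lower number from compound 2 to compound 3 (1.06 log units; beyond the scatter): the low number at this carbon therefore does not depend on a chlorine atom, since a carbon group serves equally well in this series. No supporting measurement is available to explain why chloro and methyl read alike here or why fluoro differs from both.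

The compounds shown carry only fluoro, chloro and methyl at this carbon, so they leave open how an ethyl, a methoxy, an amine or a carboxylic acid would read there. On these data alone, the chloro on the other aromatic ring is the same in compound 2, compound 3 and compound 4, so it also remains open what replacing it with a methyl or a nitrile would do to the number.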